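A few compounds are considered here, and "the series" means these few. Any claim that something is new, unique, unknown or untested is made for them only; others in the source may bear on it.

Of the compounds shown here, two from the study have numbers so far. Compound 1 `CCCCCCCC/C=C\CCCCCCC(=O)c1ncc(-c2ccccc2)o1` carries a phenyl group on the five-membered core, and in an assay on isolated protein for inhibition of Fatty-acid amide hydrolase 1 (Homo sapiens) (a higher number here means a weaker inhibitor, a lower number a stronger inhibitor), compound 1 gives 320 nM. Compound 2 `CCCCCCCC/C=C\CCCCCCC(=O)c1nc2ncccc2o1` keeps the long unsaturated ketone chain but differs in its core; in this assay compound 2 gives 2.3 nM. Of the two numbers, compound 1 stands highest: compound 2 sits far lower, a gap well beyond the scatter, so compound 1 is the weaker inhibitor of the pair.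

Compound 3 `CCCCCCCC/C=C\CCCCCCC(=O)c1ncc(-c2ccncc2)o1` has not yet been measured. It differs from compound 1 in one place: pyridin-4-yl in place of phenyl on an aromatic carbon. For the measured compounds named here, no pair of measured compounds isolates this change, so nothing in the data shows its size directly; the only known gap, between compound 1 and compound 2, concerns a different part of the molecule. For compound 3 a downward step of a 4.0-fold lower number from compound 1 to compound 3 (0.60 log units; beyond the scatter) is expected, since a ring nitrogen added at this position is thought likely to help rather than hurt, but with wide uncertainty. Compound 3 is therefore estimated at 80 nM, within a range from 20 nM to 400 nM.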

Compound 3, inhibition constant: 56 nM
Estimate against measurement, compound 3: 1.4-fold (0.15 log units) above; the measured number falls inside the stated range.
By their numbers in this assay, from the lowest: compound 2; then compound 3; then compound 1.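

For the compounds shown here, the exchange of phenyl for pyridin-4-yl gives a 5.7-fold lower number from compound 1 to compound 3 (0.76 log units; beyond the scatter) in this assay, the first step in this set that can be assigned to a single change. It shows that this position, on the aromatic carbon next to the ring oxygen, responds to what the attached ring contains: the long unsaturated ketone chain and the shared core stay the same, and a ring of carbon only gives way to one with a ring nitrogen and a hydrogen-bond acceptor. What lies behind the step cannot be said from these numbers, as no supporting measurement bears on it.

The compounds shown leave open whether the step depends on where the ring nitrogen sits, which pyridin-3-yl or pyridin-2-yl at the same carbon would address, and whether other groups on the phenyl ring, such as an amine or a carboxylic acid, would move the number in the same direction. They also leave open whether pyridin-4-yl would give a step of similar size on a different core or with a shorter chain.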